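Chloro on the benzyl ring in a shared core

The compounds below may be only part of what the source reports. "The series", "measured", "known", "first", "only" and "open" are said of these compounds alone.

Measured compounds:
Compound 1 `Cc1cc(C)c(-n2c(Cl)cn3c(CN(CCC(F)(F)F)Cc4ccccc4)c(C(F)(F)F)nc23)c(C)c1`: 43 nM
Compound 2 `Cc1cc(C)c(-n2c(Cl)cn3c(CN(CCC(F)(F)F)Cc4ccc(Cl)cc4)c(C(F)(F)F)nc23)c(C)c1`: 12 nM
Compound 3 `CCCN(Cc1ccccc1)Cc1c(C(F)(F)F)nc2n(-c3c(C)cc(C)cc3C)c(Cl)cn12`: 170 nM

In an assay on cells for displacement of a labelled ligand from corticotropin-releasing factor receptor 1 (Homo sapiens), with a stated time of 100 min (a higher number here means a weaker inhibitor, a lower number a stronger inhibitor), compound 3 gives the highest of the three numbers. Compound 1 stands in between, and the change that sets compound 3 apart from compound 1 is methyl in place of trifluoromethyl on a saturated chain carbon, two bonds along the chain from an amine nitrogen, which in this assay made a 4.0-fold higher number from compound 1 to compound 3 (0.60 log units; beyond the scatter). Compound 2 carries the change (chloro in place of hydrogen on an aromatic carbon), and that gave a 3.6-fold lower number from compound 1 to compound 2 (0.55 log units; beyond the scatter).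

Compound 4 `CCCN(Cc1ccc(Cl)cc1)Cc1c(C(F)(F)F)nc2n(-c3c(C)cc(C)cc3C)c(Cl)cn12` has not yet been measured. It differs from compound 3 by chloro in place of hydrogen on an aromatic carbon, the same change that separates compound 2 from compound 1, at the same kind of place. Resting on the step from compound 1 to compound 2 a 3.6-fold lower number from compound 1 to compound 2 (0.55 log units; beyond the scatter), the expected step for compound 4 is a 3.6-fold lower number from compound 3 to compound 4 (0.56 log units; beyond the scatter). The estimated value for compound 4 is 47 nM, with a likely range from 20 nM to 120 nM.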

Compound 4, inhibition constant: 28 nM
For compound 4 the middle estimate is 1.7-fold (0.22 log units) above the measured one; measured number inside the range.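

In this assay the chloro change carried over to the second core, giving a 6.1-fold lower number from compound 3 to compound 4 (0.78 log units; beyond the scatter), and its size matched the earlier step: the same change on two cores in this assay, a 3.6-fold lower number (0.55 log units; beyond the scatter) from compound 1 to compound 2 and a 6.1-fold lower number (0.78 log units; beyond the scatter) from compound 3 to compound 4, 1.7-fold (0.23 log units) apart, within the scatter of two such steps
With chloro present, methyl in place of trifluoromethyl gave a 2.3-fold higher number from compound 2 to compound 4 (0.37 log units; beyond the scatter), which also matched its earlier counterpart: the same change on two cores in this assay, a 4.0-fold higher number (0.60 log units; beyond the scatter) from compound 1 to compound 3 and a 2.3-fold higher number (0.37 log units; beyond the scatter) from compound 2 to compound 4, 1.7-fold (0.23 log units) apart, within the scatter of two such steps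
Both changes therefore transferred across these four compounds, but two steps per change, with chloro at one ring position, do not show that either would transfer to other cores or explain why it changes the number.

The compounds shown leave open whether bromo, methoxy or a nitrile on the same ring would behave like chloro. They also leave open what a longer chain on the amine nitrogen would do.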